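The source may hold more compounds than are shown below. What is called first, only, known or untested is meant among the compounds shown, and "the series" means these compounds.

Three compounds that differ at one place on a shared core have been tested in a functional assay on cells (Homo sapiens) for antiproliferative activity, read by WST assay, with a stated time of 3 days; a higher number here means a weaker inhibitor, a lower number a stronger inhibitor. Compound 1 `N#Cc1cc(=O)[nH]c(=O)n1[C@@H]1O[C@H](CO)[C@@H](O)[C@H]1O`, which carries cyano, gives > 50000 nM, a limit of the assay and not a number. Compound 2 `O=c1cc(I)n([C@@H]2O[C@H](CO)[C@@H](O)[C@H]2O)c(=O)[nH]1`, which carries iodo, gives 27800 nM. Compound 3 `[N-]=[N+]=Nc1cc(=O)[nH]c(=O)n1[C@@H]1O[C@H](CO)[C@@H](O)[C@H]1O`, which carries azido, gives > 50000 nM, again a limit and not a number. Compound 3 therefore has no exact position and stands at the limit of > 50000 nM in this assay, at which 2 of the 3 values shown sit.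

The next compound is compound 4 `Nc1cc(=O)[nH]c(=O)n1[C@@H]1O[C@H](CO)[C@@H](O)[C@H]1O`, with amino in place of azido on an aromatic carbon. Amino itself appears in no measured step, so only the swaps at this same place can guide the expectation. Putting iodo in place of cyano gives an at least 1.7-fold lower number from compound 1 to compound 2 (0.25 log units; that floor lies within the scatter), and putting azido in place of iodo gives an at least 1.7-fold higher number from compound 2 to compound 3 (0.25 log units; that floor lies within the scatter). Both of these floors lie within the scatter. Putting azido in place of cyano gives a step that the two limits leave unreadable from compound 1 to compound 3.

No step here is shown to exceed the scatter, so no clear step is expected in this assay, and another limit is the likeliest report. The estimated change is a number no higher from compound 3 to compound 4 (the limit leaves the size open). For compound 4 the expected value is 50000 nM, with an estimated range from 20000 nM to 100000 nM.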

Compound 4, half-maximal inhibitory concentration: > 50000 nM
Compound 4: a limit, no number (the forecaster's own chance of this, stated with the estimate: 80%); the middle value lies on the limit itself.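

In this assay, putting amino in place of iodo gives an at least 1.7-fold higher number from compound 2 to compound 4 (0.25 log units; that floor lies within the scatter), so this swap, like the earlier ones, does not show a difference beyond the usual scatter. The steps to compound 4 from compound 1 and from compound 3 cannot be read: both ends of each step are limits of the assay and not numbers. What compound 4 adds is that azido and amino differ in their heavy atoms and in their hydrogen-bond donors, yet this change on the aromatic carbon next to the ring nitrogen still leaves the result at a limit, which now covers most of the series: the limit of > 50000 nM in this assay, at which 3 of the 4 values shown sit.

As far as these compounds go, compound 2 alone gives a number, so how the other three compounds really compare with it, or with one another, stays open, as does whether any group at this place can produce a step beyond the scatter. A methylamino group, a carboxylic acid or a longer carbon chain at the same place could begin to settle that question.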